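The source may hold more compounds than are shown below. What is called first, only, known or untested is meant among the compounds shown, and "the series" means these compounds.

Compound 1 `O=C(Oc1ccc(-c2cncn2C2CCN(C(=O)c3ccc(Cl)c(C(F)(F)F)c3)CC2)cc1)c1cccc2cnccc12` gives in an assay on HEK293 cells for antagonist activity at P2X purinoceptor 7 (Homo sapiens), read by fluorescence, with a stated time of 2 h; on this read-out lower numbers stand for stronger inhibition and higher numbers for weaker inhibition > 10000 nM, which is a limit of the assay. Compound 2 `O=C(c1ccc(Cl)c(C(F)(F)F)c1)N1CCC(n2cncc2-c2ccc(OS(=O)(=O)c3cccs3)cc2)CC1` gives in this assay 238 nM.

Compound 2 thus holds the only number shown; the other value is a limit (the limit of > 10000 nM in this assay, at which 1 of the 2 values shown sits). Among the measured compounds shown here, the one measured step, an at least 42-fold lower number from compound 1 to compound 2 (1.62 log units; beyond the scatter), changed the whole group on the oxygen on an aromatic ring. Compound 3 `Nc1cccc(S(=O)(=O)Oc2ccc(-c3cncn3C3CCN(C(=O)c4ccc(Cl)c(C(F)(F)F)c4)CC3)cc2)c1` differs from compound 2 by 3-aminophenyl in place of thiophen-2-yl on a sulfonyl sulfur. For the measured compounds named here, no measured step alters the group on the sulfonyl sulfur alone, so the expected step is a 1.7-fold higher number from compound 2 to compound 3 (0.23 log units; within the scatter). For compound 3 the estimate in this assay is 400 nM, between 100 nM and 1600 nM.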

Compound 3, half-maximal inhibitory concentration: 565 nM
The estimate for compound 3 lay 1.4-fold (0.15 log units) below the measured number; measured number inside the range.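

The group on the sulfonyl sulfur matters to the read-out, since replacing thiophen-2-yl with 3-aminophenyl gives a 2.4-fold higher number from compound 2 to compound 3 (0.38 log units; beyond the scatter). The large gain from the group on the aromatic ring's oxygen persists with this second sulfonyl group, at an at least 17-fold lower number from compound 1 to compound 3 (1.24 log units; beyond the scatter). The value of compound 1 is a limit of the assay: the limit of > 10000 nM in this assay, at which 1 of the 3 values shown sits.

From the compounds shown here alone, what stays open is whether the amine or the change of ring accounts for the step, which a plain phenyl on the sulfonyl sulfur would separate. Going by these compounds, how a small methyl at that place would read also remains unknown.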